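One stereocentre inverted, cytotoxicity in question

The compounds below may be only part of what the source reports. "The series", "measured", "known", "first", "only" and "open" are said of these compounds alone.

Measured in a functional assay on A549 cells (Homo sapiens) for cytotoxicity, read by MTT assay, with a stated time of 72 h; on this read-out lower numbers stand for stronger inhibition and higher numbers for weaker inhibition:
compound 1 `COc1ccc(C(CC(=O)N[C@@H](CC(C)C)B(O)O)NC(=O)c2ccccc2)cc1`: 3450 nM
compound 2 `COc1ccc([C@H](CC(=O)N[C@@H](CC(C)C)B(O)O)NC(=O)c2ccccc2)cc1`: 3680 nM

Measured alongside compound 1, compound 2 stands level at 3680 nM, and the two cannot be told apart. Compound 3 `COc1ccc([C@@H](CC(=O)N[C@@H](CC(C)C)B(O)O)NC(=O)c2ccccc2)cc1` remains unmeasured in this assay: the two compounds have the same atoms and bonds and differ only in configuration as drawn: 1 of 2 stereo elements differ; a stereocentre at a saturated chain carbon is drawn S in compound 2 and R in compound 3. Among the measured compounds shown here, the only measured step that bears on this is a 1.1-fold higher number from compound 1 to compound 2 (0.03 log units; within the scatter), and it reflects (the fact that one of compounds 1 and 2 is drawn with a defined configuration and the other without, at the place where they differ). That step is small and does not test the R configuration directly, so no shift beyond the scatter is expected, in either direction. The expected change is a 1.1-fold lower number from compound 2 to compound 3 (0.03 log units; within the scatter). Compound 3 is estimated at 3400 nM, with an expected range of 1500 nM to 7500 nM.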

Compound 3, half-maximal inhibitory concentration: 830 nM
The estimate for compound 3 lay 4.1-fold (0.61 log units) above the measured number; measured number below the stated range.
By their numbers in this assay, from the lowest: compound 3; then compounds 1 and 2 (each within the scatter of the next).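

In this assay the configuration at this saturated chain carbon proves to matter, which the earlier pair could not show: inverting it from S to R gives a 4.4-fold lower number from compound 2 to compound 3 (0.65 log units; beyond the scatter). The R form also stands apart from the compound drawn without a configuration, with a 4.2-fold lower number from compound 1 to compound 3 (0.62 log units; beyond the scatter). Configuration is the only structural difference between the S and R forms, so the shift traces to this stereocentre: the fact that compounds 2 and 3 differ only in the configuration as drawn

The compounds shown leave open whether R keeps its edge over S when the methoxy group gives way to an amine or a carboxylic acid.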